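The source may report more compounds than this note shows. Statements on the series, on what has been measured and on what is new or still open speak of the compounds shown alone.

The account begins with two measured compounds. Compound 1, with the structure `O=C(C1CC1)N(O)c1ccc(Cl)cc1`, was tested in a functional assay on CCRF-CEM cells (Homo sapiens) for inhibition (on this read-out higher numbers stand for weaker inhibition and lower numbers for stronger inhibition), where compound 1 gave 25000 nM. Compound 2, with the structure `O=C(CC1CCCCC1)N(O)c1ccc(Cl)cc1`, was run in the same this assay, and in it compound 2 gave 16000 nM. On these two numbers compound 2 stands alongside compound 1: the gap between them lies within the usual scatter of repeated measurements, so the two values show nothing that can be called a difference.

From compound 2 the account moves to compound 3, whose structure is `O=C(CC1CCCCC1)N(O)c1ccccc1`. The change is hydrogen in place of chloro on an aromatic carbon. Within the data shown here, no step of this kind is known among the measured compounds, so the size of the effect in this assay has to be estimated rather than read from a precedent. The author expects the step to be modest, toward weaker inhibition, and close to the edge of the scatter, so that compound 3 is expected to give 30000 nM, with a range from 12000 nM to 80000 nM. That expectation for compound 3 corresponds to a 1.9-fold higher number from compound 2 to compound 3 (0.27 log units; within the scatter).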

Compound 3, half-maximal inhibitory concentration: 40000 nM
For compound 3 the middle estimate is 1.3-fold (0.12 log units) below the measured one, and the stated range covers the measured number.
By their numbers in this assay, from the lowest: compounds 2, 1 and 3 (each within the scatter of the next, the first and the last beyond it).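

Hydrogen in place of chloro, on an aromatic carbon of the six-membered aromatic ring and para to a large group, gives a 2.5-fold higher number from compound 2 to compound 3 (0.40 log units; beyond the scatter) in this assay and so marks a modest step. Compounds 1 and 2 both carry the chloro and could say nothing about this position, whereas this pair shows that, on the core of compound 2, inhibition is weaker without the chloro. This is a single pair, however, and nothing at hand gives a measured reason for the step or its size.

The compounds shown leave open whether a fluoro, a bromo, a methyl or a methoxy group at this same position would match the chloro, or would give a number closer to that of the unsubstituted ring. They also leave open whether hydrogen in place of chloro would give a step of similar size on the core of compound 1, where the group on the carbonyl differs.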